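This account rests on a few compounds, and the source may have more. Where it says the series, first, only, none or still open, it means among the compounds named here.

Compound 1 `Cc1ccc(S(=O)(=O)NC(C)C2=CC(=O)c3c(O)ccc(O)c3C2=O)cc1`: 5340 nM
Compound 2 `Cc1ccccc1S(=O)(=O)NC(C)C1=CC(=O)c2c(O)ccc(O)c2C1=O`: 4490 nM
Compound 3 `CC(NS(=O)(=O)c1ccccc1Br)C1=CC(=O)c2c(O)ccc(O)c2C1=O`: 6200 nM

In a functional assay on HeLa cells (Homo sapiens) for cytotoxicity, read by sulforhodamine B assay (a lower number here means a stronger inhibitor, a higher number a weaker inhibitor), compound 1 gives 5340 nM and lies within the scatter of both other compounds, as a 1.2-fold lower number from compound 1 to compound 2 (0.08 log units; within the scatter) and a 1.2-fold higher number from compound 1 to compound 3 (0.06 log units; within the scatter) show. Compound 4 `CCOC(=O)c1ccc(S(=O)(=O)NC(C)C2=CC(=O)c3c(O)ccc(O)c3C2=O)cc1` carries ethoxycarbonyl in place of methyl on an aromatic carbon, para to a large group: ethoxycarbonyl in place of methyl on an aromatic carbon. The nearest evidence is those two steps, together with a 1.4-fold higher number from compound 2 to compound 3 (0.14 log units; within the scatter), all of which change the group on the sulfonyl sulfur. Going by these compounds, none of them brings in ethoxycarbonyl, so this group remains untested. No step beyond the scatter is therefore expected, and the estimate is a 1.1-fold lower number from compound 1 to compound 4 (0.03 log units; within the scatter). Compound 4 is expected at 5000 nM, with an estimated range of 2200 nM to 11000 nM.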

Compound 4, half-maximal inhibitory concentration: 2260 nM
Estimate against measurement, compound 4: 2.2-fold (0.34 log units) above; measured number inside the range.
By their numbers in this assay, from the lowest: compounds 4, 2, 1 and 3 (each within the scatter of the next, the first and the last beyond it).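

In this assay, among these compounds, ethoxycarbonyl in place of methyl on an aromatic carbon, para to a large group, gives a 2.4-fold lower number from compound 1 to compound 4 (0.37 log units; beyond the scatter) and is the first single change here to reach beyond the scatter. The earlier steps shown here, which exchanged the aryl group on the sulfonyl sulfur, stayed within it, so this position does respond to the group it carries. Nothing measured here accounts for this step.

Going by these compounds, it remains open whether the carbonyl or the ethyl part carries the step. A carboxylic acid or an amide at this place could separate the two, while an amine or a nitrile would test other groups there.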